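Acetyl for trifluoromethyl in a cytotoxicity series

This account rests on a few compounds, and the source may have more. Where it says the series, first, only, none or still open, it means among the compounds named here.

Compound 1 `Cc1nc(C(NC(=O)C(=O)Nc2ccc(C(F)(F)F)cc2)C2CCCCN2)sc1CO`: > 75500 nM
Compound 2 `Cc1ccc(NC(=O)C(=O)NC(c2nc(C)c(CCO)s2)C2CCCCN2)c(F)c1`: > 78800 nM
Compound 3 `Cc1nc(C(NC(=O)C(=O)Nc2ccc(Cl)cc2)C2CCNCC2)sc1CCO`: 85400 nM

Of the compounds shown here, three have been measured in an ADME assay on TZM-b1 cells (Homo sapiens) for cytotoxicity, read by XTT assay, with a stated time of 3 days; on this read-out lower numbers stand for higher toxicity in this test and higher numbers for lower toxicity in this test. Compound 1 `Cc1nc(C(NC(=O)C(=O)Nc2ccc(C(F)(F)F)cc2)C2CCCCN2)sc1CO` gives > 75500 nM in this assay, and this value is a limit of the assay rather than a number. Compound 2 `Cc1ccc(NC(=O)C(=O)NC(c2nc(C)c(CCO)s2)C2CCCCN2)c(F)c1` gives > 78800 nM, again a limit of the assay. For the measured compounds named here, compound 3 `Cc1nc(C(NC(=O)C(=O)Nc2ccc(Cl)cc2)C2CCNCC2)sc1CCO` gives 85400 nM, the one value among the three that is a number. Compound 1 thus stands at one of the two limits shown (the limit of > 75500 nM in this assay, at which 1 of the 3 values shown sits), and the other limit of > 78800 nM in this assay, at which 1 of the 3 values shown sits, lies close to it, so the three measured values all sit in the same high region of this assay.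

Compound 4 `CC(=O)c1ccc(NC(=O)C(=O)NC(c2nc(C)c(CO)s2)C2CCCCN2)cc1` differs from compound 1 by acetyl in place of trifluoromethyl on an aromatic carbon. Going by the values given here, no step between two measured compounds is available in this assay, so no measured effect of a change of this kind can be pointed to. With all three measured values sitting at or near the top of the assay, the step that the limit leaves unreadable from compound 1 to compound 4 is expected to be none beyond the scatter. Compound 4 is expected at 80000 nM, within 50000 nM to 150000 nM, and is most likely to be reported as a limit once more.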

Compound 4, half-maximal cytotoxic concentration: > 86000 nM
Compound 4: a limit, no number; the forecaster's own chance of this, stated with the estimate: 75%; middle value at least 1.0-fold (0.03 log units) from the limit.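

In this assay compound 4 gives > 86000 nM, which is a limit and not a number. Compound 1 also stands at a limit, and no step can be read between compound 1 and compound 4. The compounds shown leave open whether acetyl in place of trifluoromethyl changes the half-maximal cytotoxic concentration at all.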